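This account rests on a few compounds, and the source may have more. Where it says the series, first, only, none or still open, it means among the compounds named here.

Compound 1 `CCc1ccccc1-n1nc(C)c2c1NC(=O)[C@H](C)S[C@@H]2c1ccc(Oc2ccccc2)cc1`: 1100 nM
Compound 2 `COc1cccc(-c2ccc([C@H]3S[C@@H](C)C(=O)Nc4c3c(C)nn4-c3ccccc3C)cc2)c1`: 1800 nM
Compound 3 `COc1ccccc1-c1ccc([C@H]2S[C@@H](C)C(=O)Nc3c2c(C)nn3-c2ccccc2C)cc1`: 1100 nM

In an assay on isolated protein for agonist activity at Bile acid receptor (Homo sapiens), read by AlphaScreen, with a stated time of 30 min (on this read-out lower numbers stand for an effect already at smaller amounts and higher numbers for an effect only at larger amounts of compound), compound 3 stands level with compound 1 at the digits shown, and the two together give the lowest of the three numbers; the only single-point step among the measured compounds, a 1.6-fold lower number from compound 2 to compound 3 (0.21 log units; within the scatter), is within the scatter. Compound 4 `Cc1ccccc1-n1nc(C)c2c1NC(=O)[C@H](C)S[C@@H]2c1ccc(-c2ccco2)cc1` is compound 3 with furan-2-yl in place of 2-methoxyphenyl on an aromatic carbon. Among the compounds with values here, no measured pair differs in this way: the step of a 1.6-fold lower number from compound 2 to compound 3 (0.21 log units; within the scatter) concerns the methoxy position and moved nothing beyond the scatter, while compound 1 differs from compound 3 in more than one place. The step of a 1.4-fold higher number from compound 3 to compound 4 (0.13 log units; within the scatter) is therefore expected to be small, with a wide range for lack of a bearing step. Compound 4 is estimated at 1500 nM, between 500 nM and 5000 nM.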

Compound 4, half-maximal effective concentration: 3600 nM
For compound 4 the middle estimate is 2.4-fold (0.38 log units) below the measured one, within the range that was stated.
By their numbers in this assay, from the lowest: compounds 1, 3, 2 and 4 (each within the scatter of the next, the first and the last beyond it).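

Within the data shown here, at this place, para to a large group, furan-2-yl in place of 2-methoxyphenyl gives the first step beyond the scatter in this assay (a 3.3-fold higher number from compound 3 to compound 4 (0.51 log units; beyond the scatter)), so the group held here can move the number. Measured against the 3-methoxyphenyl group, the same exchange stays within the scatter (a 2.0-fold higher number from compound 2 to compound 4 (0.30 log units; within the scatter)), so the size of the step depends on the methoxyphenyl group it is read from. No measurement bears on the reason for this result.

Going by these compounds, whether the five-membered aromatic ring or the furan oxygen matters remains open. A thiophene or a pyridine ring at this place, or an amine on the outer ring, would help to separate the two.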